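This account rests on a few compounds, and the source may have more. Where it says the series, first, only, none or still open, it means among the compounds named here.

Measured so far in a physicochemical assay for lipophilicity; on this read-out lower numbers stand for lower lipophilicity and higher numbers for higher lipophilicity:
Compound 1 `CCCOC(=O)c1ccc(S(N)(=O)=O)cc1` has 1.75 as its value
Compound 2 `CCCCCOC(=O)c1ccc(S(N)(=O)=O)cc1` has 2.71 as its value
Compound 3 `CCCCNC(=O)c1ccc(S(N)(=O)=O)cc1` has 1.05 as its value

Compound 3 stands lowest of the three, and its neighbours are both clearly higher. Compound 4 `CCCCCNC(=O)c1ccc(S(N)(=O)=O)cc1` is not yet measured. It differs from compound 3 as follows: methyl in place of hydrogen on a saturated chain carbon, four bonds along the chain from an amide-type nitrogen.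

The closest guide is a similar chain extension, ethyl in place of hydrogen, which gave a number 0.96 log units higher from compound 1 to compound 2 (beyond the scatter). That chain, however, hangs from an oxygen rather than a nitrogen. The two other steps, a number 0.70 log units lower from compound 1 to compound 3 (beyond the scatter) and a number 1.66 log units lower from compound 2 to compound 3 (beyond the scatter), swap the link itself and say less here. Methyl is the smaller addition, so a smaller upward step is expected, a number 0.48 log units higher from compound 3 to compound 4 (beyond the scatter). For compound 4 the estimated value is 1.53 with an expected range from 1.25 to 1.85 on this scale.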

Compound 4, partition coefficient: 1.54
Estimate against measurement, compound 4: 0.01 log units below; measured number inside the range.
By their numbers in this assay, from the lowest: compound 3; then compounds 4 and 1 (each within the scatter of the next); then compound 2.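

In this assay one more methyl on the chain gives a number 0.49 log units higher from compound 3 to compound 4 (beyond the scatter) so a chain on an amide-type nitrogen also rises with added carbon. Going by these compounds alone, with pentyl on both sides, pentylamino in place of pentyloxy gives a number 1.17 log units lower from compound 2 to compound 4 (beyond the scatter) and this is the first view of that swap with the chain length unchanged. Pentylamino in place of propoxy gives a number 0.21 log units lower from compound 1 to compound 4 (within the scatter) so these two groups cannot be told apart here. Going by these compounds, whether a hexyl chain on the nitrogen continues this rise stays open, as does the outcome for a chain ending in an amine or a carboxylic acid. Nothing available gives a reason for any of these steps.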